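The source may hold more compounds than are shown below. What is called first, only, known or untested is meant among the compounds shown, and "the series" means these compounds.

Compound 1 `CC(C)Sc1nc(Cc2c(F)cccc2F)cc(=O)[nH]1`: in a functional assay on MT4 cells (Homo sapiens) for cytotoxicity (on this read-out higher numbers stand for lower toxicity in this test and lower numbers for higher toxicity in this test), compound 1 gives > 200000 nM, which is a limit of this assay and not a number.
Compound 2 `O=c1cc(Cc2c(F)cccc2F)nc(SC2CCCC2)[nH]1`: in this assay compound 2 gives > 200000 nM, also a limit.
Compound 3 `CC(C)Sc1nc(O)cc(C(C)c2cccc3ccccc23)n1`: in this assay compound 3 gives 119000 nM.

Compounds 1 and 2 share a core and differ in one place, (cyclopentyl in place of isopropyl on a sulfur). Both sit at the limit of > 200000 nM in this assay, at which 2 of the 3 values shown sit, so the step that the two limits leave unreadable from compound 1 to compound 2 cannot be read. Compound 3 carries a different core, and the difference between the two cores is not broken down here. Compound 4 `CC(c1cc(O)nc(SC2CCCC2)n1)c1cccc2ccccc12` is not yet measured in this assay; it differs from compound 3 by cyclopentyl in place of isopropyl on a sulfur, the same change as between compounds 1 and 2.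

Going by the values given here, since the only measured instance of this change gives no readable size, the expectation for compound 4 in this assay rests on compound 3 alone, with its value of 119000 nM, and the step of a 1.0-fold higher number from compound 3 to compound 4 (0.00 log units; within the scatter) is estimated as small. Compound 4 is therefore expected to give about 120000 nM, between 50000 nM and 250000 nM.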

Compound 4, half-maximal cytotoxic concentration: 93000 nM
Compound 4: middle estimate off by 1.3-fold (0.11 log units), on the high side, within the range that was stated.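

On the core of compound 3, putting cyclopentyl in place of isopropyl on a sulfur gives a 1.3-fold lower number from compound 3 to compound 4 (0.11 log units; within the scatter) in this assay, so the two values cannot be told apart. This does not show that the change behaves the same way on another core, because the same change on the core of compounds 1 and 2 cannot be read, each of those two values being a limit of the assay and not a number: the limit of > 200000 nM in this assay, at which 2 of the 4 values shown sit.
Going by these compounds alone, the step from the core of compound 3 is therefore the only readable instance of this change, and its size cannot be compared across the two cores.

The compounds shown leave open how this read-out responds when the group on the sulfur is neither isopropyl nor cyclopentyl, for example a longer chain such as n-butyl, or a chain ending in an amine or a carboxylic acid. They also leave open whether such groups would give a readable number on the core of compounds 1 and 2.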